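Cyano to fluoro swap: metabolic stability outlook

The source may report more compounds than this note shows. Statements on the series, on what has been measured and on what is new or still open speak of the compounds shown alone.

Measured compounds:
- compound 1, `COc1ccc(-c2c(S(=O)(=O)c3cccc(F)c3)cnc3cc(F)ccc23)cc1`: 1.89 mL/min
- compound 2, `N#Cc1cccc(S(=O)(=O)c2cnc3cc(F)ccc3c2-c2cccc(F)c2)c1`: 0.78 mL/min

Both compounds were run in an ADME assay on microsomes from liver (Homo sapiens) for metabolic stability, tested at 2.5 uM; a higher number here means faster removal of the compound, a lower number slower removal. In this assay compound 2 gives 0.78 mL/min, the lowest of the two numbers; compound 1 gives 1.89 mL/min, and the gap between the two lies beyond the scatter of repeated measurements. Within the data shown here, no pair of measured compounds differs in only one place, so no single-point step is available within the set.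

Compound 3, `O=S(=O)(c1cccc(F)c1)c1cnc2cc(F)ccc2c1-c1cccc(F)c1`, is next for this assay. It differs from compound 2 by one change:

fluoro in place of cyano on an aromatic carbon

Read one bond further out, the change is 3-cyanophenyl to 3-fluorophenyl. Nothing among the two measured compounds tests this exchange on its own, so the expectation rests on the value of compound 2 alone rather than on any shown step. The step expected from compound 2 to compound 3 is a 1.4-fold higher number from compound 2 to compound 3 (0.15 log units; within the scatter), a slight upward shift that is not expected to exceed the usual scatter. For compound 3 the estimated value in this assay is 1.1 mL/min, with a range of 0.55 mL/min to 2.2 mL/min.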

Compound 3, intrinsic clearance in a liver preparation (reported as CLH), per the amount of preparation that the assay uses: 0.24 mL/min
Beside the measured number, compound 3's estimate is 4.6-fold (0.66 log units) above it; measured number outside the range, below it.
By their numbers in this assay, from the lowest: compound 3; then compound 2; then compound 1.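

With compound 3, the series gains its first steps that change one place, read in this assay. Fluoro in place of cyano, on an aromatic carbon of a six-membered aromatic ring of carbon only and meta to a large group, gives a 3.3-fold lower number from compound 2 to compound 3 (0.51 log units; beyond the scatter) and shows that the read-out responds to the group at this position. The exchange of 4-methoxyphenyl for 3-fluorophenyl gives a 7.9-fold lower number from compound 1 to compound 3 (0.90 log units; beyond the scatter), which leaves compound 3 with the lowest number of the three, though nothing at hand accounts for either step.

Only one exchange at the cyano position is shown, so it remains open how a chloro, an amine or a carboxylic acid on the same aromatic carbon would read in this assay, and whether the fluoro-for-cyano step would repeat with 4-methoxyphenyl in place of 3-fluorophenyl. The compounds shown also cannot separate the contribution of the methoxy group from that of its location on the ring, a question that a 4-fluorophenyl or 3-methoxyphenyl analogue would address directly.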